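Swapping the aryl group on a pyridazinone amide

The source may hold more compounds than are shown below. What is called first, only, known or untested is meant among the compounds shown, and "the series" means these compounds.

Compound 1 `Cc1cc(=O)n(-c2ccc(F)c(F)c2)nc1C(=O)Nc1ccc(Oc2ncnc3sccc23)cc1`: 16800 nM
Compound 2 `Cc1cc(=O)n(-c2ccccc2OC(F)(F)F)nc1C(=O)Nc1ccc(Oc2ncnc3sccc23)c(F)c1`: > 40000 nM
Compound 3 `Cc1ccc(-n2nc(C(=O)Nc3ccc(Oc4ncnc5sccc45)c(F)c3)c(C)cc2=O)cc1`: > 40000 nM

In a functional assay on HepG2 cells (Homo sapiens) for cytotoxicity, read by MTT assay, with a stated time of 72 h (a higher number here means a weaker inhibitor, a lower number a stronger inhibitor), compound 1 gives 16800 nM. Compound 2 reaches only the limit of the assay, > 40000 nM. Compound 3 likewise stops at the limit, > 40000 nM, so its place among the numbers is known only as a limit; of the three values shown, two sit at this limit (the limit of > 40000 nM in this assay, at which 2 of the 3 values shown sit). For the measured compounds named here, the one measured step that touches compound 3, a step that the two limits leave unreadable from compound 2 to compound 3, cannot be read in size, as both ends are limits.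

Compound 4 `Cc1cc(=O)n(-c2ccc(F)c(F)c2)nc1C(=O)Nc1ccc(Oc2ncnc3sccc23)c(F)c1` differs from compound 3 in one place: 3,4-difluorophenyl in place of 4-methylphenyl on an aromatic nitrogen. Going by the values given here, no measured step shows this exchange, so the step of an at least 1.3-fold lower number from compound 3 to compound 4 (0.12 log units; that floor lies within the scatter) that the estimate implies rests on the value of compound 1, which carries the same 3,4-difluorophenyl and gives 16800 nM. For compound 3 itself only a limit is known. Compound 4 is therefore expected to fall near 30000 nM, with a range from 10000 nM to 90000 nM, and a real chance that this assay again reports only a limit.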

Compound 4, half-maximal inhibitory concentration: > 40000 nM
Compound 4: no number, only a limit; the forecaster's own chance of this, stated with the estimate: 45%; at least 1.3-fold (0.12 log units) between middle value and limit.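

In this assay, replacing 4-methylphenyl with 3,4-difluorophenyl on the aromatic nitrogen yields no readable number, as compound 4 gives only a limit, > 40000 nM. The steps to compound 4 from compound 2 and from compound 3 cannot be read, since both ends of each are limits. The one readable step, fluoro in place of hydrogen on an aromatic carbon with 3,4-difluorophenyl kept, is an at least 2.3-fold higher number from compound 1 to compound 4 (0.37 log units; beyond the scatter), so 3,4-difluorophenyl alone does not secure a number, and the three fluoro-bearing compounds end alike: the limit of > 40000 nM in this assay, at which 3 of the 4 values shown sit.

Where compound 2, compound 3 and compound 4 truly lie stays open, so their aryl groups cannot be ranked against one another. Also open, from the compounds shown here alone, is whether an amine or a carboxylic acid on that aryl group would give a number with the fluoro in place.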